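The source may report more compounds than this note shows. Statements on the series, on what has been measured and on what is new or still open speak of the compounds shown alone.

Compound 3 `CNS(=O)(=O)[C@@H]1CC[C@@H](Nc2ncc3c(Br)nn(-c4ccc5ncccc5c4)c3n2)C1` gives 106 nM in an assay on SK-OV-3 cells for inhibition of eIF-2-alpha kinase GCN2 (Homo sapiens) (on this read-out higher numbers stand for weaker inhibition and lower numbers for stronger inhibition), which is the higher of the two numbers recorded; compound 1 `COCCNC(=O)[C@@H]1CC[C@@H](Nc2ncc3c(Br)nn(-c4ccc5ncccc5c4)c3n2)C1` gives 20 nM in this assay, and compound 2 `COCc1noc([C@@H]2CC[C@@H](Nc3ncc4c(Br)nn(-c5ccc6ncccc6c5)c4n3)C2)n1` gives "nd" (no result reported) in this assay, that is, no reported result. Compound 4 `CNC(=O)[C@]1(C)CC[C@@H](Nc2ncc3c(Br)nn(-c4ccc5ncccc5c4)c3n2)C1` differs from compound 3 by a group of 10 heavy atoms (8 carbon, 1 nitrogen, 1 oxygen; one five-membered non-aromatic ring of carbon only) in place of a group of 10 heavy atoms (6 carbon, 1 nitrogen, 2 oxygen, 1 sulfur; one five-membered non-aromatic ring of carbon only), on a nitrogen on an aromatic ring. Within the data shown here, the one measured step that bears on this is a 5.3-fold higher number from compound 1 to compound 3 (0.72 log units; beyond the scatter), where the carbamoyl-bearing compound gave the lower number. Among the measured compounds shown here, compound 4 returns to a carbamoyl group, which suggests a recovery toward compound 1, though the added methyl on the ring carbon has no precedent here. Compound 4 is therefore expected to show a 3.0-fold lower number from compound 3 to compound 4 (0.48 log units; beyond the scatter), giving an estimate of 35 nM with a range from 10 nM to 120 nM.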

Compound 4, half-maximal inhibitory concentration: 21 nM
For compound 4 the middle estimate is 1.7-fold (0.22 log units) above the measured one, within the range that was stated.
By their numbers in this assay, from the lowest: compounds 1 and 4 (each within the scatter of the next); then compound 3.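

In this assay the step gives a 5.0-fold lower number from compound 3 to compound 4 (0.70 log units; beyond the scatter), so a group with a carbamoyl and a ring methyl reads lower than the methylsulfamoyl group on this nitrogen on an aromatic ring. Compound 1 at 20 nM and compound 4 at 21 nM lie within the scatter of each other, so the added ring methyl comes with no visible loss. No measurement offered here explains this step. Still open, as far as these compounds go, is what the ring methyl contributes on its own, and how an amine or a carboxylic acid on that saturated ring carbon would read in this assay.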